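The source may report more compounds than this note shows. Statements on the series, on what has been measured and on what is new or still open speak of the compounds shown alone.

Series notes. Compound 1 `CC(C)(C)OC(=O)N1CCC2(CC1)CC(CCCOc1ccc(S(C)(=O)=O)c(F)c1)C2` gives 9 nM in a functional assay on cells for agonist activity at Glucose-dependent insulinotropic receptor (Homo sapiens), read by HTRF and cAMP accumulation, with a stated time of 30 min; on this read-out higher numbers stand for an effect only at larger amounts of compound and lower numbers for an effect already at smaller amounts. Compound 2 `CC(C)OC(=O)N1CCC2(CC1)CC(CCCOc1ccc(S(C)(=O)=O)c(F)c1)C2` gives 18 nM in this assay, and compound 3 `CCc1cnc(N2CCC3(CC2)CC(CCCOc2ccc(S(C)(=O)=O)c(F)c2)C3)nc1` gives 123 nM. Compound 2 stands second highest of the three numbers: the step of a 2.0-fold higher number from compound 1 to compound 2 (0.30 log units; within the scatter) lies within the scatter, whereas the step of a 6.8-fold higher number from compound 2 to compound 3 (0.83 log units; beyond the scatter) lies beyond it. The step of a 14-fold higher number from compound 1 to compound 3 (1.14 log units; beyond the scatter) concerns the same amine nitrogen in a ring.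

Compound 4 `CC(C)OC(=O)N1CCC2(CC1)CC(CCCOc1ccc(C(N)=O)c(F)c1)C2` differs from compound 2 by carbamoyl in place of methylsulfonyl on an aromatic carbon. Among the compounds with values here, none of the measured steps touches this position: all three exchange the group on the amine nitrogen in a ring and keep the aryl substituent fixed, so they give no direct guide to the present change. The aromatic substituent is therefore expected to carry a step of its own, estimated at a 3.1-fold higher number from compound 2 to compound 4 (0.49 log units; beyond the scatter), a modest rise in the number. For compound 4 the expected value in this assay is 55 nM, with a range from 15 nM to 250 nM.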

Compound 4, half-maximal effective concentration: 52 nM
Estimate against measurement, compound 4: 1.1-fold (0.02 log units) above; the measured number falls inside the stated range.
By their numbers in this assay, from the lowest: compounds 1 and 2 (each within the scatter of the next); then compound 4; then compound 3.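

Within the data shown here, the step of a 2.9-fold higher number from compound 2 to compound 4 (0.46 log units; beyond the scatter) is the first measured at this aromatic carbon, with isopropoxycarbonyl held fixed on the amine nitrogen in a ring, and it shows that the aryl substituent moves the number in this assay independently of that nitrogen group. Methylsulfonyl is not the only group workable here: with carbamoyl, which brings a hydrogen-bond donor that methylsulfonyl lacks, compound 4 still gives 52 nM, though the rise lies beyond the scatter. Nothing measured on these compounds accounts for the size of this step.

From the compounds shown here alone, whether the same exchange gives a similar step with tert-butoxycarbonyl or 5-ethylpyrimidin-2-yl on the nitrogen remains open. Also open, going by these compounds, is how a nitrile or a carboxylic acid at this aromatic carbon would compare with carbamoyl and methylsulfonyl.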